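Nitro to bromo exchange on a cyanoacetyl series

This account rests on a few compounds, and the source may have more. Where it says the series, first, only, none or still open, it means among the compounds named here.

Compound 1 `N#CCC(=O)N/N=C(/CBr)c1ccc(Br)cc1` and compound 2 `N#CCC(=O)N/N=C(/CBr)c1ccc([N+](=O)[O-])cc1` share an open-chain core; compound 3 `N#CCC1=C(C#N)CC(c2ccc([N+](=O)[O-])cc2)=C(CC(=O)c2ccc([N+](=O)[O-])cc2)O1` is built on a ring-closed core, and the difference between the two cores is not broken down here. In a functional assay on MCF7 cells (Homo sapiens) for inhibition, read by sulforhodamine B assay, with a stated time of 48 h (a higher number here means a weaker inhibitor of growth, a lower number a stronger inhibitor of growth), compound 1 gives 40600 nM, while compound 2 gives 18400 nM. The change from compound 2 to compound 1 is bromo in place of nitro on an aromatic carbon, and it made a 2.2-fold higher number from compound 2 to compound 1 (0.34 log units; beyond the scatter). Compound 3 gives 30 nM in this assay, far from both open-chain compounds; against compound 1 the gap is widest.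

Compound 4 `N#CCC1=C(C#N)CC(c2ccc([N+](=O)[O-])cc2)=C(CC(=O)c2ccc(Br)cc2)O1` differs from compound 3 by bromo in place of nitro on an aromatic carbon, the same change as that from compound 2 to compound 1, though it is now carried on the ring-closed core. Given the small step already seen between compound 2 and compound 1 a 2.2-fold higher number from compound 2 to compound 1 (0.34 log units; beyond the scatter), compound 4 is expected to sit close to compound 3, with the step from compound 3 to compound 4 estimated at a 2.0-fold higher number from compound 3 to compound 4 (0.30 log units; within the scatter) in this assay. The estimate for compound 4 in this assay is therefore 60 nM, with an expected range from 20 nM to 200 nM.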

Compound 4, concentration for 50% growth inhibition: 4900 nM
Compound 4: middle estimate off by 82-fold (1.91 log units), on the low side; the whole stated range lies below it.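

In this assay, bromo in place of nitro on an aromatic carbon gives a 160-fold higher number from compound 3 to compound 4 (2.21 log units; beyond the scatter), a large step on the core of compound 3. The size of this change does not carry over between the two cores: the same change on two cores in this assay, a 2.2-fold higher number (0.34 log units; beyond the scatter) from compound 2 to compound 1 and a 160-fold higher number (2.21 log units; beyond the scatter) from compound 3 to compound 4, 74-fold (1.87 log units) apart, beyond the scatter of two such steps. The direction is the same in both pairs, with bromo giving the higher number, but two pairs show only that the size of the step differs with the core, not which feature of the cores sets it, nor how the change would behave on any other core.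

From the compounds shown here alone, compound 4 still carries a nitro group on its other aromatic ring, so it remains open whether replacing that second nitro with bromo would give a step of similar size. Also open, going by these compounds, is how an amine, a methoxy group or a chloro substituent at the same place would read on each core, and whether the gap between the two steps would hold in another cell line.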